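Propyl to Butyl on the Amine: One Carbon Further

This account rests on a few compounds, and the source may have more. Where it says the series, first, only, none or still open, it means among the compounds named here.

Among the compounds with values here, compound 1 `CCCNC(=C\C(=O)/C=C/c1ccc(O)c(OC)c1)/C=C/c1ccc(O)c(OC)c1` is one of two compounds measured in a functional assay on Caco-2 cells (Homo sapiens), read by fluorescence, tested at 10 uM; on this read-out higher numbers stand for a weaker effect at the one concentration tested and lower numbers for a stronger effect. In this assay compound 1 gives 88%, the highest of the two numbers, while compound 2 `O=C(/C=C(/C=C/c1ccc(O)cc1)NC1CCCCC1)/C=C/c1ccc(O)cc1` gives 82%, a gap within the scatter, so the two cannot be ordered. Compound 3 `CCCCNC(=C\C(=O)/C=C/c1ccc(O)c(OC)c1)/C=C/c1ccc(O)c(OC)c1` differs from compound 1 by methyl in place of hydrogen on a saturated chain carbon, three bonds along the chain from an amine nitrogen. Within the data shown here, no step between measured compounds is available to guide the expectation, so the author expects no shift beyond the scatter, a number 1 percentage points lower from compound 1 to compound 3 (within the scatter). Compound 3 is therefore estimated at 87%, expected to lie between 75% and 98%.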

Compound 3, a percentage reported as activity, at one concentration (the size of the read-out at that concentration, not a potency): 83%
Compound 3: the middle estimate sits 4 percentage points above what was measured; the range from low to high includes it.
By their numbers in this assay, from the lowest: compounds 2, 3 and 1 (each within the scatter of the next).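

Within the data shown here, the change from propyl to butyl gives the first step that can be read at this position: in this assay the step is a number 5 percentage points lower from compound 1 to compound 3 (within the scatter), so methyl in place of hydrogen on a saturated chain carbon, three bonds along the chain from an amine nitrogen, has no effect beyond the scatter at this one concentration. No supporting evidence bears on this result.

The compounds shown leave open whether a longer chain, such as hexyl, would give a step beyond the scatter. They also leave open what a carboxylic acid at the end of the chain would do.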